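Para-alkyl swap on the aryl ring of a hydroxamate sulfamide

A few compounds are considered here, and "the series" means these few. Any claim that something is new, unique, unknown or untested is made for them only; others in the source may bear on it.

Measured compounds:
Compound 1, `O=C(NO)[C@H]1CCCCN1S(=O)(=O)N1CC=C(c2ccccc2)CC1`, gives 240 nM.
Compound 2, `O=C(NO)[C@H]1CCCCN1S(=O)(=O)N1CC=C(c2ccc(Br)cc2)CC1`, gives 1200 nM.
Compound 3, `CCc1cccc(C2=CCN(S(=O)(=O)N3CCCC[C@@H]3C(=O)NO)CC2)c1`, gives 320 nM.

These three numbers come from a functional assay on MONO-MAC-6 cells (Homo sapiens) for inhibition; on this read-out lower numbers stand for stronger inhibition and higher numbers for weaker inhibition. Compound 3 stands second highest of the three: its value and that of compound 1 lie within the scatter of each other, while compound 2 sits clearly higher, as the step of a 3.8-fold lower number from compound 2 to compound 3 (0.57 log units; beyond the scatter) shows.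

Compound 4, `CCCc1ccc(C2=CCN(S(=O)(=O)N3CCCC[C@@H]3C(=O)NO)CC2)cc1`, differs from compound 3 in one place: 4-propylphenyl in place of 3-ethylphenyl on a double-bonded ring carbon. For the measured compounds named here, two measured steps bear on this. The step of a 5.0-fold higher number from compound 1 to compound 2 (0.70 log units; beyond the scatter) shows that a group on the 4-position of the phenyl ring raised the number, and the step of a 1.3-fold higher number from compound 1 to compound 3 (0.12 log units; within the scatter) shows that an ethyl group at the 3-position hardly mattered. A propyl group at the 4-position is therefore expected to push the value up, modestly, in the direction set by compound 2 and its 1200 nM. The estimate for compound 4 is 800 nM, with a range from 300 nM to 2500 nM, which means an expected step of a 2.5-fold higher number from compound 3 to compound 4 (0.40 log units; beyond the scatter).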

Compound 4, half-maximal inhibitory concentration: 2600 nM
For compound 4 the middle estimate is 3.3-fold (0.51 log units) below the measured one, outside the stated range (above it).
By their numbers in this assay, from the lowest: compounds 1 and 3 (each within the scatter of the next); then compound 2; then compound 4.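

In this assay, 4-propylphenyl raises the number by more than 4-bromophenyl does: the step from the plain phenyl is large (an 11-fold higher number from compound 1 to compound 4 (1.03 log units; beyond the scatter)), and propyl in place of bromo adds to it (a 2.2-fold higher number from compound 2 to compound 4 (0.34 log units; beyond the scatter)). Two phenyl groups that both carry a small carbon chain can therefore behave very differently here, since 3-ethylphenyl stays within the scatter of the plain phenyl, while the change to 4-propylphenyl is a clear rise (an 8.1-fold higher number from compound 3 to compound 4 (0.91 log units; beyond the scatter)). Nothing measured here explains this rise.

The compounds shown leave open whether a longer chain in the propyl group's place would raise the number further. They also leave open whether a propyl chain ending in an amine or a carboxylic acid would give a similar value.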